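The source may hold more compounds than are shown below. What is called first, only, known or untested is meant among the compounds shown, and "the series" means these compounds.

In an ADME assay on CEM-SS cells (Homo sapiens) for cytotoxicity, read by XTT assay, with a stated time of 6 days (a higher number here means that more compound is tolerated, a lower number that less compound is tolerated), compound 1 `CCCC(=O)OCSc1ccccc1C(=O)NCCCCC(N)=O` gives 51.7 uM, the higher of two single numbers, as compound 2 `CCCC(=O)OCSc1ccccc1C(=O)NCCCCCCNC(C)=O` gives 8 uM. For the measured compounds named here, that pair supplies the only measured step, a 6.5-fold lower number from compound 1 to compound 2 (0.81 log units; beyond the scatter), but its change is 2-acetamidoethyl in place of carbamoyl on a saturated chain carbon, so it bears only loosely on what follows. Compound 3 `CCCC(=O)OCSc1ccccc1C(=O)N[C@H]1CCC[C@H]1C(N)=O` gives 89.9 uM; 84.8 uM (2 entries) in two entries that lie close together. Compound 4 `CCCC(=O)OCSc1ccccc1C(=O)N[C@@H]1CCC[C@@H]1C(N)=O` has not yet been measured. It differs from compound 1 by 2-carbamoylcyclopentyl in place of 4-carbamoylbutyl on an amide-type nitrogen. Compound 3 carries the same 2-carbamoylcyclopentyl, with its defined stereocentres set the opposite way, and this makes it the closest guide. Given the 89.9 uM; 84.8 uM (2 entries) of compound 3, no step beyond the scatter is expected in this assay. The expected change is small, a 1.5-fold higher number from compound 1 to compound 4 (0.16 log units; within the scatter). For compound 4 the estimated value is 75 uM, with an expected range from 35 uM to 150 uM.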

Compound 4, half-maximal toxic concentration: 90 uM
The estimate for compound 4 lay 1.2-fold (0.08 log units) below the measured number; low and high end bracket the measured number.
By their numbers in this assay, from the lowest: compound 2; then compounds 1 and 4 (each within the scatter of the next).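

In this assay, 2-carbamoylcyclopentyl in place of 4-carbamoylbutyl on the amide-type nitrogen leaves the number within the scatter, with a 1.7-fold higher number from compound 1 to compound 4 (0.24 log units; within the scatter). Setting the defined stereocentres the opposite way also shows no separation, as compound 3 gives 89.9 uM; 84.8 uM (2 entries) and compound 4 gives 90 uM, values that lie close together for a pair set apart by one feature alone: the fact that compounds 3 and 4 differ only in the configuration as drawn. This agreement rests on more than a single reading of the comparison compound: the several entries of compound 3 in this assay, 89.9 uM; 84.8 uM (2 entries).

As far as these compounds go, whether a carboxylic acid or an amine in place of the carbamoyl of 2-carbamoylcyclopentyl would keep the number at this level remains open. Also open, from the compounds shown here alone, is whether a longer chain ending in carbamoyl would stay near compound 1 or come closer to compound 2 at 8 uM.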